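The compounds below may be only part of what the source reports. "The series", "measured", "known", "first", "only" and "open" are said of these compounds alone.

Compound 1 `COc1ccc(/C=C/C(=O)/C=C/c2cc3ccccc3nc2Oc2ccccc2)cc1` was tested in a functional assay on HeLa cells (Homo sapiens) for cytotoxicity, read by MTT assay, with a stated time of 48 h; on this read-out higher numbers stand for weaker inhibition and lower numbers for stronger inhibition. In this assay compound 1 reaches only the limit of the assay, > 10000 nM. Compound 2 `COc1ccc(/C=C/C(=O)/C=C/c2cc3ccccc3nc2Oc2ccccc2)c(OC)c1` differs from it by methoxy in place of hydrogen on an aromatic carbon. In this assay compound 2 likewise gives only a limit, > 10000 nM. Compound 3 `COc1ccc(/C=C/C(=O)/C=C/c2cc3ccccc3nc2Oc2ccc(Br)cc2)cc1` differs from compound 1 by bromo in place of hydrogen on an aromatic carbon. In this assay compound 3 also sits at a limit, > 10000 nM. The step that the two limits leave unreadable from compound 1 to compound 2 and the step that the two limits leave unreadable from compound 1 to compound 3 therefore cannot be read, because the limit of > 10000 nM in this assay, at which 3 of the 3 values shown sit, holds all three values.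

Compound 4 `COc1ccc(/C=C/C(=O)/C=C/c2cc3ccccc3nc2Oc2ccc(Br)cc2)c(OC)c1` has not been measured in this assay. It differs from compound 3 by methoxy in place of hydrogen on an aromatic carbon, the same change as that from compound 1 to compound 2, and the two cores differ by bromo in place of hydrogen on an aromatic carbon. Since the step from compound 1 to compound 2 could not be read, the step that the limit leaves unreadable from compound 3 to compound 4 is expected to be of unreadable size as well, with compound 4 most likely remaining at the limit. On that basis compound 4 is estimated at 20000 nM, between 8000 nM and 60000 nM.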

Compound 4, half-maximal inhibitory concentration: > 10000 nM
Compound 4: a limit, no number; the forecaster's own chance of this, stated with the estimate: 85%; the middle value lies beyond the limit too.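

In this assay compound 4 gives > 10000 nM as a limit and not a number. Among the compounds shown here, no new step to compound 4 can be read, from compound 3 or from compound 2, because every value stays at the same limit: the limit of > 10000 nM in this assay, at which 4 of the 4 values shown sit. The compounds shown leave open how strongly any of them inhibits, and whether methoxy or bromo in place of hydrogen alters that at all.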